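Fluoro substitution on a potent serotonin receptor antagonist

A few compounds are considered here, and "the series" means these few. Any claim that something is new, unique, unknown or untested is made for them only; others in the source may bear on it.

Compound 1 `Cc1noc(-c2ccccc2NC(=O)OCC2CCN(CCNS(C)(=O)=O)CC2)n1` is the stronger of two measured compounds: in an assay on Esophagus for antagonist activity at 5-hydroxytryptamine receptor 4 (Rattus norvegicus) (a lower number here means a less potent compound, a higher number a more potent compound, by a factor of ten per unit of this negative logarithm), compound 1 gives 10.8. Going by the values given here, its only measured relative, compound 2 `COc1ccc(NC(=O)OCC2CCN(CCNS(C)(=O)=O)CC2)c(-c2nc(C)no2)c1`, gives 8.1 in this assay, and the single step, a number 2.70 log units lower from compound 1 to compound 2 (beyond the scatter), came from a methoxy in place of hydrogen on an aromatic carbon. Compound 3 `Cc1noc(-c2ccc(F)cc2NC(=O)OCC2CCN(CCNS(C)(=O)=O)CC2)n1` differs from compound 1 by fluoro in place of hydrogen on an aromatic carbon. The methoxy step bears on it only loosely: it shows that the ring of compound 1 tolerates added groups poorly, but the methoxy sits at a different place and is a larger group than fluoro, so a much smaller loss is expected, about a number 0.50 log units lower from compound 1 to compound 3 (beyond the scatter), possibly none beyond the scatter. Compound 3 is therefore estimated at 10.3, between 9.3 and 11.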

Compound 3, negative logarithm of the antagonist equilibrium constant: 8.9
For compound 3 the middle estimate is 1.40 log units above the measured one; the whole stated range lies above it.
By their numbers in this assay, from the lowest: compound 2; then compound 3; then compound 1.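

The change adds only one heavy atom, a fluoro on the aromatic carbon para to the 3-methyl-1,2,4-oxadiazol-5-yl group, yet it brings a number 1.90 log units lower from compound 1 to compound 3 (beyond the scatter) in this assay. Going by these compounds alone, this position, left unchanged in the earlier compounds, therefore does not take even this single-atom replacement of hydrogen without a large loss, so the high number of compound 1 depends on what happens at this carbon. No measurement at hand explains the loss.

As far as these compounds go, it remains open whether a chloro, methyl or hydroxyl group on this same carbon would cost as much as fluoro. From the compounds shown here alone, it is also open how fluoro would fare on the aromatic carbon that carries the methoxy in compound 2, a comparison that would separate the effect of the group from the effect of its place.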